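Chain length and cyanoguanidine swap in pyridazinone series

A few compounds are considered here, and "the series" means these few. Any claim that something is new, unique, unknown or untested is made for them only; others in the source may bear on it.

Compound 1 `C/N=C(\S)NCCCCCn1nc(-c2ccccc2)ccc1=O` carries the shorter chain; in a functional assay on the whole organism with Rattus norvegicus as the target, at a dose of 100 mg/kg (a lower number here means less inhibition, a higher number more inhibition at the dose given (going by the name of the read-out)), compound 1 gives 68.9%. Compound 2 `CC/N=C(/NC#N)NCCCCn1nc(-c2ccccc2)ccc1=O` differs from compound 1 by a group of 8 heavy atoms (4 carbon, 4 nitrogen; no ring) in place of a group of 6 heavy atoms (3 carbon, 2 nitrogen, 1 sulfur; no ring), on a saturated chain carbon, four bonds along the chain from an aromatic nitrogen, and in this assay compound 2 gives 58.8%; the step is a number 10.1 percentage points lower from compound 1 to compound 2 (beyond the scatter). Compound 3 `C/N=C(\S)NCCCCCCn1nc(-c2ccccc2)ccc1=O` differs from compound 1 by a group of 6 heavy atoms (3 carbon, 2 nitrogen, 1 sulfur; no ring) in place of a group of 5 heavy atoms (2 carbon, 2 nitrogen, 1 sulfur; no ring), on a saturated chain carbon, five bonds along the chain from an aromatic nitrogen, and in this assay compound 3 gives 22.2%, the lowest of the three numbers; the step is a number 46.7 percentage points lower from compound 1 to compound 3 (beyond the scatter), and from compound 2 the step is a number 36.6 percentage points lower from compound 2 to compound 3 (beyond the scatter).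

Compound 4 `CC/N=C(/NC#N)NCCCCCn1nc(-c2ccccc2)ccc1=O` is not yet measured in this assay. It differs from compound 3 by a group of 8 heavy atoms (4 carbon, 4 nitrogen; no ring) in place of a group of 6 heavy atoms (3 carbon, 2 nitrogen, 1 sulfur; no ring), on a saturated chain carbon, five bonds along the chain from an aromatic nitrogen. Among the measured compounds shown here, this is the same kind of change as the one from compound 1 to compound 2, but not the same: there the group sat four bonds along the chain from an aromatic nitrogen, here it sits five bonds along. The difference between the two cores of compound 1 and compound 3 is a group of 6 heavy atoms (3 carbon, 2 nitrogen, 1 sulfur; no ring) in place of a group of 5 heavy atoms (2 carbon, 2 nitrogen, 1 sulfur; no ring), on a saturated chain carbon, five bonds along the chain from an aromatic nitrogen.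

With one occurrence of this kind of change, the expectation for compound 4 rests on the step from compound 1 to compound 2, a number 10.1 percentage points lower from compound 1 to compound 2 (beyond the scatter), applied to compound 3 at 22.2%. The step from compound 3 to compound 4 is expected to be a number 8.2 percentage points lower from compound 3 to compound 4 (within the scatter). For the measured compounds named here, compound 4 is estimated at 14%, with a range from 0% to 38%, because the single precedent a number 10.1 percentage points lower from compound 1 to compound 2 (beyond the scatter) is itself only modest and the longer-chain pair differs in place.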

Compound 4, a percentage reported as inhibition, in the whole organism at one dose (the size of the read-out at that dose, not a potency): 48.2%
The estimate for compound 4 lay 34.2 percentage points below the measured number; measured number above the stated range.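

Carrying the group of 8 heavy atoms (4 carbon, 4 nitrogen) in place of the group of 6 heavy atoms (3 carbon, 2 nitrogen, 1 sulfur) from one core to another does not give a step of fixed size or direction in this assay: the same change on two cores in this assay, a number 10.1 percentage points lower (beyond the scatter) from compound 1 to compound 2 and a number 26 percentage points higher (beyond the scatter) from compound 3 to compound 4, 36.1 percentage points apart, beyond the scatter of two such steps. On the core of compound 3 the change reads as a number 26 percentage points higher from compound 3 to compound 4 (beyond the scatter), yet this rise does not restore the top number of the series, as the change on an amine nitrogen shows with a number 20.7 percentage points lower from compound 1 to compound 4 (beyond the scatter). With only these two occurrences, each at a single dose in the whole organism, the notes show that a step taken from one core is a poor guide on the other, but they do not show what sets its direction or give a rule for other cores.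

Still open, on these data alone, is whether the direction of the step follows chain length, which would need a longer chain carrying the group of 8 heavy atoms and a shorter chain carrying the sulfur-bearing group. Also open, as far as these compounds go, is how a simple amine or a carboxylic acid at the chain end would read on these same cores.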